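A few compounds are considered here, and "the series" means these few. Any claim that something is new, unique, unknown or untested is made for them only; others in the source may bear on it.

In an ADME assay on L02 cells (Homo sapiens) for inhibition, read by CCK-8 assay, with a stated time of 48 h (on this read-out lower numbers stand for stronger inhibition of growth and higher numbers for weaker inhibition of growth), compound 1 (`Cc1ccccc1Nc1nc(Nc2ccc(N3CCN(C)CC3)cn2)ncc1Cl`) gives 5980 nM and compound 2 (`CN1CCN(c2ccc(Nc3ncc(Cl)c(NCc4ccccc4)n3)nc2)CC1`) gives 20300 nM while compound 3 (`Cc1cccc(Nc2nc(Nc3ccc(N4CCN(C)CC4)cn3)ncc2Cl)c1`) gives 6080 nM on the same core. Compound 3 therefore stands level with compound 1, and the numbers show a 3.3-fold lower number from compound 2 to compound 3 (0.52 log units; beyond the scatter) as its gap to the remaining compound. Compound 4 (`CN1CCN(c2ccc(Nc3ncc(Cl)c(Nc4ccc(C(C)(C)C)cc4)n3)nc2)CC1`) keeps the core and changes one group: 4-(tert-butyl)phenyl in place of 3-methylphenyl on a nitrogen on an aromatic ring with 4-(tert-butyl)phenyl in place of 3-methylphenyl on a nitrogen on an aromatic ring. Two measured steps at this nitrogen bear on the change. Putting 3-methylphenyl in place of 2-methylphenyl gave a 1.0-fold higher number from compound 1 to compound 3 (0.01 log units; within the scatter) and stayed within the scatter, whereas benzyl in place of 2-methylphenyl gave a 3.4-fold higher number from compound 1 to compound 2 (0.53 log units; beyond the scatter) as a modest step. For the measured compounds named here, compound 4 keeps a phenyl on the nitrogen as compound 1 and compound 3 do, but no measured compound carries 4-(tert-butyl)phenyl, so the expectation is uncertain. No step beyond the scatter is expected, and the estimate is a 1.2-fold lower number from compound 3 to compound 4 (0.08 log units; within the scatter) in this assay here. For compound 4 the estimated value is 5000 nM within an expected range from 2000 nM to 12000 nM in this read-out.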

Compound 4, concentration for 50% growth inhibition: 6070 nM
For compound 4 the middle estimate is 1.2-fold (0.08 log units) below the measured one; the measured number falls inside the stated range.
By their numbers in this assay, from the lowest: compounds 1, 4 and 3 (each within the scatter of the next); then compound 2.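

In this assay, the bulkier count of 4-(tert-butyl)phenyl, at 10 heavy atoms against 7 for 3-methylphenyl, changes nothing that can be told from scatter: the result is a 1.0-fold lower number from compound 3 to compound 4 (0.00 log units; within the scatter) and a 1.0-fold higher number from compound 1 to compound 4 (0.01 log units; within the scatter). So far, then, this nitrogen tolerates a methyl or a tert-butyl on the phenyl ring without any real shift, while benzyl remains the one group set apart, as a 3.3-fold lower number from compound 2 to compound 4 (0.52 log units; beyond the scatter) shows, and none of the four compounds goes against this. Nothing available explains why these numbers stay level or why benzyl differs.

Open, on these data alone, is whether a phenyl ring carrying an amine or a carboxylic acid would stay level with compound 4. Also open, as far as these compounds go, is whether a longer chain between the nitrogen and the ring would move the number further than benzyl does in compound 2.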